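This account rests on a few compounds, and the source may have more. Where it says the series, first, only, none or still open, it means among the compounds named here.

Measured compounds:
compound 1, `Clc1ccc(Sc2ccc(NC3=NCCN3)cc2)cc1`, 79.4 nM
compound 2, `O=C(O)c1ccc(Sc2ccc(NC3=NCCN3)cc2)cc1`, < 10000 nM

In an assay (Rattus norvegicus) for binding affinity to prostacyclin receptor (Homo sapiens), read by radioligand binding (on this read-out higher numbers stand for weaker inhibition and lower numbers for stronger inhibition), compound 1 gives 79.4 nM. For compound 2 the read-out is only a limit, < 10000 nM. Because of the limit of < 10000 nM in this assay, at which 1 of the 2 values shown sits, the step that the limit leaves unreadable from compound 1 to compound 2 cannot be read, so on the numbers shown compound 2 stands at that limit and nowhere more exact. Compound 3, `CS(=O)(=O)Nc1ccc(Sc2ccc(NC3=NCCN3)cc2)cc1`, differs from compound 2 by methanesulfonamido in place of carboxy on an aromatic carbon. Within the data shown here, no measured step bears readably on this change, as the single recorded step is itself unreadable, so neither size nor direction of the step in this assay can be drawn from the measured pairs. The estimate therefore rests on compound 1, which in this assay gives 79.4 nM. It also takes into account that the read-out for compound 2 is only a limit. The expected step that the limit leaves unreadable from compound 2 to compound 3 is an estimate only. Compound 3 is expected to give about 500 nM, within 50 nM to 5000 nM.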

Compound 3, inhibition constant: 79.4 nM
For compound 3 the middle estimate is 6.3-fold (0.80 log units) above the measured one; the measured number falls inside the stated range.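

In this assay, the exchange of chloro for methanesulfonamido on this aromatic carbon, para to a large group, gives a readable result: no change at the digits printed from compound 1 to compound 3 (within the scatter). Among these compounds, the position therefore accepts two quite different groups on the shared core with no difference beyond the scatter, which the earlier compounds, with only one readable value between them, could not show. The steps that involve compound 2 cannot be read, so nothing can be said of how carboxy compares with either of the other groups: the limit of < 10000 nM in this assay, at which 1 of the 3 values shown sits.

The compounds shown leave open how an amine, a carboxamide or a longer chain such as ethanesulfonamido would read at this position. As far as these compounds go, it also remains open whether the hydrogen on the sulfonamide nitrogen matters, a question that an N-methyl methanesulfonamido group would address.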